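Chloro for dimethylamino on a chalcone-type core

The source may report more compounds than this note shows. Statements on the series, on what has been measured and on what is new or still open speak of the compounds shown alone.

Compound 1 `CN(C)c1ccc(C(=O)/C=C/c2ccncc2)cc1` gives 11000 nM in a functional assay with Rattus norvegicus as the target; on this read-out higher numbers stand for weaker inhibition and lower numbers for stronger inhibition. Compound 2 `O=C(/C=C/c1ccncc1)c1cccs1` gives 30000 nM.

Compound 1 stands lowest of the two numbers; the number for compound 2 is higher, and the gap lies beyond the scatter. Compound 3 `O=C(/C=C/c1ccncc1)c1ccc(Cl)cc1` has not yet been measured. It differs from compound 1 by chloro in place of dimethylamino on an aromatic carbon. Among the compounds with values here, with no step between measured compounds to lean on, the step is expected to be small, at most modest toward a higher number, so that a 1.4-fold higher number from compound 1 to compound 3 (0.13 log units; within the scatter) is the estimate. Compound 3 is therefore expected to give about 15000 nM, within a range from 5000 nM to 45000 nM.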

Compound 3, half-maximal inhibitory concentration: 60000 nM
Beside the measured number, compound 3's estimate is 4.0-fold (0.60 log units) below it; the measured number lies above the stated range.
By their numbers in this assay, from the lowest: compound 1; then compounds 2 and 3 (each within the scatter of the next).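

In this assay, chloro in place of dimethylamino on this aromatic carbon, para to a large group, gives a 5.5-fold higher number from compound 1 to compound 3 (0.74 log units; beyond the scatter) and so a step beyond the scatter. This shows that the position is sensitive to the group it carries, and that of these two groups dimethylamino gives the lower number. No available evidence bears on what lies behind this step. Going by these compounds, whether a methoxy group, a primary amine or plain hydrogen at this position would stay nearer compound 1 or compound 3 remains open.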